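A Larger Substituent on the Shared Core

A few compounds are considered here, and "the series" means these few. Any claim that something is new, unique, unknown or untested is made for them only; others in the source may bear on it.

Of the compounds shown here, three built on one shared core have been tested in a functional assay (aorta) with Rattus norvegicus as the target; on this read-out higher numbers stand for an effect only at larger amounts of compound and lower numbers for an effect already at smaller amounts. Compound 1 `COc1ccc(-c2nc(CNC(C)=O)sc2-c2ccc(OC)cc2)cc1` gives 8.1 uM, the second highest of the three numbers. Compound 2 `COc1ccc(-c2nc(C(=O)N3CCCCC3CCO)sc2-c2ccc(OC)cc2)cc1` gives 6.8 uM, and compound 3 `COc1ccc(-c2nc(C(=O)N3CCN(C(=O)NC(C)C)CC3)sc2-c2ccc(OC)cc2)cc1` gives 15 uM; both of these values lie within the usual scatter of the value of compound 1, so the three cannot be told apart on this read-out. Compound 4 `CCOC(=O)/C(C#N)=C/c1nc(-c2ccc(OC)cc2)c(-c2ccc(OC)cc2)s1` has not yet been measured. It differs from compound 1 in one place: 2-cyano-2-(ethoxycarbonyl)ethenyl in place of acetamidomethyl on an aromatic carbon. For the measured compounds named here, no measured pair shows the effect of such a change, so there is no step to lean on. Compound 4 is therefore expected to give 8 uM, between 3 uM and 25 uM. This estimate means a step of a 1.0-fold lower number from compound 1 to compound 4 (0.01 log units; within the scatter) that is expected to stay within the scatter.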

Compound 4, concentration for half-maximal effect: > 100 uM
Compound 4: only a limit was reported; the forecaster's own chance of this, stated with the estimate: 10%; at least 12-fold (1.09 log units) between middle value and limit.
By their numbers in this assay, from the lowest: compounds 2, 1 and 3 (each within the scatter of the next, the first and the last beyond it). At a limit, above all of these: compound 4.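

Replacing acetamidomethyl with 2-cyano-2-(ethoxycarbonyl)ethenyl on this aromatic carbon gives an at least 12-fold higher number from compound 1 to compound 4 (1.09 log units; beyond the scatter), the first step shown at this position, so the read-out does respond to the group placed there. In this assay compound 4 gives > 100 uM, which is a limit and not a number: the limit of > 100 uM in this assay, at which 1 of the 4 values shown sits.

The entering group differs at once in heavy atoms, hydrogen-bond donors and acceptors, and multiple bonds, and the compounds shown do not separate these differences. On these data alone, whether a carboxylic acid or a simple amine at this position would retain an effect remains open.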